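Notes on the series: fluoro in place of methyl

The source may hold more compounds than are shown below. What is called first, only, known or untested is meant among the compounds shown, and "the series" means these compounds.

Measured in a functional assay on A549 cells (Homo sapiens) for antiproliferative activity, read by MTT assay, with a stated time of 72 h; a lower number here means a stronger inhibitor, a higher number a weaker inhibitor:
- compound 1 `COc1cc(-n2cnc3ccc(-c4ccc([N+](=O)[O-])cc4)cc32)cc(OC)c1OC`: 8940 nM
- compound 2 `COc1cc(-n2cnc3ccc(-c4ccc(C(F)(F)F)cc4)cc32)cc(OC)c1OC`: 3390 nM
- compound 3 `COc1cc(-n2cnc3ccc(-c4cccc(C)c4)cc32)cc(OC)c1OC`: 3820 nM

In this assay, compound 3 sits level with compound 2, with a 1.1-fold higher number from compound 2 to compound 3 (0.05 log units; within the scatter). Compound 1 stands apart, with a 2.3-fold lower number from compound 1 to compound 3 (0.37 log units; beyond the scatter).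

The next compound is compound 4 `COc1cc(-n2cnc3ccc(-c4cccc(F)c4)cc32)cc(OC)c1OC`, which has fluoro in place of methyl on an aromatic carbon, meta to a large group: fluoro in place of methyl on an aromatic carbon. For the measured compounds named here, no measured step makes this exchange directly, so the evidence comes from the other changes to the same aromatic substituent. The closest is the other step that removes the 3-methylphenyl group, a 1.1-fold higher number from compound 2 to compound 3 (0.05 log units; within the scatter). Going by the values given here, the only steps beyond the scatter both start from compound 1 and are modest: a 2.6-fold lower number from compound 1 to compound 2 (0.42 log units; beyond the scatter) and a 2.3-fold lower number from compound 1 to compound 3 (0.37 log units; beyond the scatter). Compound 4 keeps no nitro group, so neither of these points to a large move. No step beyond the scatter is therefore expected in this assay, and no direction is favoured.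

The expected step is a 1.0-fold lower number from compound 3 to compound 4 (0.01 log units; within the scatter). For compound 4 the estimated value is 3700 nM, with an expected range of 1900 nM to 7200 nM.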

Compound 4, half-maximal inhibitory concentration: 5270 nM
Estimate against measurement, compound 4: 1.4-fold (0.15 log units) below, within the range that was stated.
By their numbers in this assay, from the lowest: compounds 2, 3, 4 and 1 (each within the scatter of the next, the first and the last beyond it).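

In this assay, for the compounds shown here, this is the first direct reading of fluoro in place of methyl on this aromatic carbon, meta to a large group, and the exchange stays within the scatter (a 1.4-fold higher number from compound 3 to compound 4 (0.14 log units; within the scatter)). The 3-fluorophenyl group also stays within the scatter of both groups on the other side of the series (a 1.6-fold higher number from compound 2 to compound 4 (0.19 log units; within the scatter); a 1.7-fold lower number from compound 1 to compound 4 (0.23 log units; within the scatter)), so the separation that compound 1 showed from compound 2 and compound 3 does not extend to compound 4, and the 3-methylphenyl to 3-fluorophenyl exchange gives no readable difference at this place. No available data bear on why these steps are small.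

Only methyl and fluoro are shown on this carbon, so it remains open how an amine, a carboxylic acid or a longer chain would read at the same place. All the numbers shown come from a single cell line, so whether the exchange stays equally small in other cells also remains open.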